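Sulfonamide nitrogen swap: from compound 2 to compound 4

The source may report more compounds than this note shows. Statements on the series, on what has been measured and on what is new or still open speak of the compounds shown alone.

Measured so far in a functional assay on NCI-H460 cells (Homo sapiens) for antiproliferative activity, read by sulforhodamine B assay, with a stated time of 72 h; on this read-out lower numbers stand for stronger inhibition and higher numbers for weaker inhibition
- compound 1 `O=S(=O)(Nc1ncccn1)c1ccc(Nc2nncc3ccccc23)cc1` gives 33 nM
- compound 2 `O=S(=O)(Nc1nccs1)c1ccc(Nc2nncc3ccccc23)cc1` gives 39 nM
- compound 3 `Fc1ccc(Nc2nncc3ccccc23)cc1` gives 8.8 nM

Compound 2 (39 nM) sits within the scatter of compound 1 (33 nM), while compound 3 (8.8 nM) gives a lower number, beyond the scatter. The next compound to be read is compound 4 `Cc1cc(NS(=O)(=O)c2ccc(Nc3nncc4ccccc34)cc2)no1` in which 5-methyl-1,2-oxazol-3-yl stands in place of 1,3-thiazol-2-yl on a sulfonamide nitrogen (5-methyl-1,2-oxazol-3-yl in place of 1,3-thiazol-2-yl on a sulfonamide nitrogen). For the measured compounds named here, the only measured step at this place is a 1.2-fold higher number from compound 1 to compound 2 (0.07 log units; within the scatter) and it lies within the scatter. Compound 3 has no sulfonamide nitrogen and does not bear on this change. Going by the values given here, no measured compound carries 5-methyl-1,2-oxazol-3-yl, and a single step is thin ground, so the range is kept wide. Expected in this assay is a 1.0-fold higher number from compound 2 to compound 4 (0.01 log units; within the scatter) and no shift in either direction beyond the scatter. For compound 4 the estimated value is 40 nM (expected range 15 nM to 100 nM).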

Compound 4, half-maximal inhibitory concentration: 28 nM
Estimate against measurement, compound 4: 1.4-fold (0.15 log units) above; low and high end bracket the measured number.
By their numbers in this assay, from the lowest: compound 3; then compounds 4, 1 and 2 (each within the scatter of the next).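

In this assay, 5-methyl-1,2-oxazol-3-yl on the sulfonamide nitrogen gives a 1.4-fold lower number from compound 2 to compound 4 (0.14 log units; within the scatter) and a 1.2-fold lower number from compound 1 to compound 4 (0.07 log units; within the scatter). With a third group at this place, the series now includes a swap of ring sulfur for ring oxygen and an added methyl, and compounds 1, 2 and 4 still cannot be told apart in this read-out, with none of the three going against that. Nothing available accounts for this flat reading at the sulfonamide nitrogen.

On these data alone, all three groups here are aromatic rings, so it remains open whether a plain methyl group or a morpholine ring on the same nitrogen would stay within this narrow band. Also open, as far as these compounds go, is what the methyl contributes, which a comparison with plain 1,2-oxazol-3-yl would settle.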